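The source may hold more compounds than are shown below. What is called first, only, known or untested is meant among the compounds shown, and "the series" means these compounds.

Compound 1 `CCCCCCc1c(O)n(O)c(=O)c2ccccc12` was tested in an ADME assay on MT4 cells (Homo sapiens) for cytotoxicity, read by MTT assay (a lower number here means that less compound is tolerated, a higher number that more compound is tolerated), and in this assay compound 1 gives 128000 nM. Within the data shown here, of the two compounds with a number so far, compound 1 stands highest. The other, compound 2 `CCCC1C(=O)N(O)C(=O)c2ccccc21`, gives 25400 nM in this assay, a value that lies beyond the usual scatter from that of compound 1, so compound 1 is the one tolerated at the higher concentration. Compound 2 differs from compound 1 in more than one place, so the gap between them cannot be read as a single step.

Compound 3 `O=c1c2ccccc2c(Cc2ccccc2)c(O)n1O` has not yet been measured in this assay. It differs from compound 1 in one place: phenyl in place of pentyl on a saturated chain carbon bound to an aromatic carbon. Among the measured compounds shown here, no measured pair shows this kind of exchange, so the numbers give no guide to its effect. Both groups carry a similar count of heavy atoms and neither adds donors or acceptors, so the expected step from compound 1 to compound 3 is a 1.3-fold lower number from compound 1 to compound 3 (0.11 log units; within the scatter), within the scatter or a little toward a lower number. Compound 3 is therefore expected to give about 100000 nM in this assay, with a range from 40000 nM to 250000 nM.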

Compound 3, half-maximal cytotoxic concentration: 88000 nM
Compound 3: middle estimate off by 1.1-fold (0.06 log units), on the high side; the range from low to high includes it.
By their numbers in this assay, from the lowest: compound 2; then compounds 3 and 1 (each within the scatter of the next).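

In this assay, among these compounds, the exchange of pentyl for phenyl on a saturated chain carbon bound to an aromatic carbon gives the first step that can be read at a single place, and it comes to a 1.5-fold lower number from compound 1 to compound 3 (0.16 log units; within the scatter), which keeps compound 1 and compound 3 within the scatter of each other. The earlier pair could not show this, as compound 1 and compound 2 differ in more than one place, whereas here an open chain and one six-membered aromatic ring of carbon only, both without hydrogen-bond donors or acceptors and without net charge, give values that this assay does not tell apart at this place. The data hold no independent measurement that would account for this result, so the step stands as an observation only.

This single exchange leaves open whether a group that brings in hydrogen-bond donors, acceptors or a charge, such as an amine or a carboxylic acid, would give a value beyond the scatter at this place, and whether a longer chain would do so. It also leaves open which of the several differences between compound 1 and compound 2 goes with the gap between their values.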